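Acetoxybutyl ester in the HeLa cytotoxicity series

The compounds below may be only part of what the source reports. "The series", "measured", "known", "first", "only" and "open" are said of these compounds alone.

In a functional assay on HeLa cells (Homo sapiens) for cytotoxicity, read by MTT assay (a higher number here means a weaker inhibitor, a lower number a stronger inhibitor), compound 1 `CC(C)=CC[C@@H](OC(=O)CCO)C1=CC(=O)c2c(O)ccc(O)c2C1=O` gives 67600 nM, compound 2 `COC(C)CO[C@H](CC=C(C)C)C1=CC(=O)c2c(O)ccc(O)c2C1=O` gives 53400 nM and compound 3 `CC(=O)OCCO[C@H](CC=C(C)C)C1=CC(=O)c2c(O)ccc(O)c2C1=O` gives 41500 nM. Compound 1 therefore stands level with the other two, since none of its steps leaves the scatter.

The change to compound 4 `CCCC(CC(=O)O[C@H](CC=C(C)C)C1=CC(=O)c2c(O)ccc(O)c2C1=O)OC(C)=O` is 1-acetoxybutyl in place of hydroxymethyl on a saturated chain carbon bound to a carbonyl carbon.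

Among the compounds with values here, no measured step makes this exact change. The closest is a 1.6-fold lower number from compound 1 to compound 3 (0.21 log units; within the scatter), which also brings in an acetoxy-bearing group, as 2-acetoxyethyl. The other two, a 1.3-fold lower number from compound 1 to compound 2 (0.10 log units; within the scatter) and a 1.3-fold lower number from compound 2 to compound 3 (0.11 log units; within the scatter), are equally small. Within the data shown here, with only three compounds and a narrow spread, the data give no sign of a large step in this assay, though the longer chain has no measured precedent.

The expected change is small and within the scatter, a 1.6-fold lower number from compound 1 to compound 4 (0.21 log units; within the scatter). For compound 4 the estimated value is 42000 nM, with an expected range of 15000 nM to 90000 nM.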

Compound 4, half-maximal inhibitory concentration: 51200 nM
Estimate against measurement, compound 4: 1.2-fold (0.09 log units) below; the measured number falls inside the stated range.
By their numbers in this assay, from the lowest: compounds 3, 4, 2 and 1 (each within the scatter of the next).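

Within the data shown here, compound 4 gives the first reading at the saturated chain carbon bound to a carbonyl carbon with the ester linkage of compound 1 kept, whereas compound 2 and compound 3 differ from compound 1 at the oxygen on a saturated carbon. In this assay the step (a 1.3-fold lower number from compound 1 to compound 4 (0.12 log units; within the scatter)) shows that 1-acetoxybutyl, with 8 heavy atoms and no hydrogen-bond donor, can replace hydroxymethyl, with 2 heavy atoms and one donor, without a change beyond the scatter. No available evidence bears on this result.

As far as these compounds go, whether a carboxylic acid, an amine or 1-hydroxybutyl at this position would move the number beyond the scatter remains open. With no step in the series beyond the scatter, the compounds shown also leave open which structural changes, if any, matter in this assay.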